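Extending the ester chain from compound 3 to compound 4

The source may hold more compounds than are shown below. What is called first, only, known or untested is meant among the compounds shown, and "the series" means these compounds.

In a functional assay on SEM cells (Homo sapiens) for cytotoxicity, with a stated time of 72 h (on this read-out lower numbers stand for an effect already at smaller amounts and higher numbers for an effect only at larger amounts of compound), compound 1 `C=C[C@@](C)(/C=C/c1ccc(O)cc1)CC/C=C(C)/C=N/N` gives > 36600 nM as a limit. Compound 2 `C=C[C@@](C)(/C=C/c1ccc(O)cc1)CC/C=C(\C)CO` gives > 36600 nM as a limit too. Compound 3 `C=C[C@@](C)(/C=C/c1ccc(O)cc1)CC/C=C(\C)C(=O)OCC` stands at > 36600 nM as a limit as well, so it offers no number to start from. Among the compounds with values here, the series so far shows the limit of > 36600 nM in this assay, at which 3 of the 3 values shown sit, and nothing more. Compound 4 `C=C[C@@](C)(/C=C/c1ccc(O)cc1)CC/C=C(C)/C=C/C(=O)OCC` differs by 2-(ethoxycarbonyl)ethenyl in place of ethoxycarbonyl on a double-bonded chain carbon bound to a double-bonded chain carbon and a saturated chain carbon with 2-(ethoxycarbonyl)ethenyl in place of ethoxycarbonyl on a double-bonded chain carbon. The measured steps bearing on this are a step that the two limits leave unreadable from compound 2 to compound 3 and a step that the two limits leave unreadable from compound 1 to compound 3 and a step that the two limits leave unreadable from compound 1 to compound 2 with no size to carry over. No shift beyond the scatter is therefore expected in this assay and no direction can be set. The expected step is a step that the limit leaves unreadable from compound 3 to compound 4 on this estimate. Compound 4 is estimated at 40000 nM within the expected range (12000 nM to 80000 nM) and will most likely be reported as a limit.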

Compound 4, half-maximal effective concentration: > 36600 nM
Compound 4 ended at the assay's limit; the forecaster's own chance of this, stated with the estimate: 75%; the middle value is on the limit's open side.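

Within the data shown here, compound 4 gives > 36600 nM, a limit, as do compound 1, compound 2 and compound 3, so no step among them can be read. The compounds shown leave open whether any change to the shared core gives a measurable value in this assay.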